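A few compounds are considered here, and "the series" means these few. Any claim that something is new, unique, unknown or untested is made for them only; others in the source may bear on it.

Of the compounds shown here, three have so far been measured in a functional assay on K562 cells (Homo sapiens) for cytotoxicity; on this read-out lower numbers stand for stronger inhibition of growth and higher numbers for weaker inhibition of growth. Compound 1 `OCC#Cc1ccccc1C#Cc1ccccc1` gives 26000 nM in this assay. Compound 2 `OCCCCC#Cc1ccccc1C#Cc1ccccc1` gives 21100 nM, and compound 3 `COc1ccccc1C#Cc1ccccc1C#CCCCCO` gives 15500 nM. Among these three numbers compound 2 is neither the highest nor the lowest; its nearest neighbour is compound 1 and its furthest is compound 3, and both distances fall inside the usual scatter. The step of a 1.2-fold lower number from compound 1 to compound 2 (0.09 log units; within the scatter) went with 3-hydroxypropyl in place of hydroxy on a saturated chain carbon bound to a triple-bonded carbon, and the step of a 1.4-fold lower number from compound 2 to compound 3 (0.13 log units; within the scatter) went with methoxy in place of hydrogen on an aromatic carbon.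

Compound 4 `OCCCCC#Cc1ccccc1C#Cc1ccccn1` has not yet been measured. It differs from compound 2 in one place: pyridin-2-yl in place of phenyl on a triple-bonded carbon. Neither measured step touches this kind of exchange; both concern other parts of the molecule, and both stayed inside the scatter. There is thus no measured basis for expecting a step beyond the scatter in this assay in either direction. The estimate for compound 4 in this assay is therefore 20000 nM, with a range from 8000 nM to 50000 nM. That estimate means an expected step of a 1.1-fold lower number from compound 2 to compound 4 (0.02 log units; within the scatter), inside the scatter.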

Compound 4, concentration for 50% growth inhibition: 29000 nM
For compound 4 the middle estimate is 1.5-fold (0.16 log units) below the measured one; measured number inside the range.
By their numbers in this assay, from the lowest: compounds 3, 2, 1 and 4 (each within the scatter of the next).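

In this assay, putting pyridin-2-yl in place of phenyl on a triple-bonded carbon gave a 1.4-fold higher number from compound 2 to compound 4 (0.14 log units; within the scatter). For the compounds shown here, the earlier steps changed the chain and added methoxy on an aromatic carbon, whereas this is the first step to exchange the ring on the triple-bonded carbon itself, bringing in one ring nitrogen and one hydrogen-bond acceptor where phenyl has none; this exchange, like those two steps, stays inside the scatter, so the number shows no clear response to it. Nothing available bears on this result or on what part, if any, the ring nitrogen plays.

The compounds shown leave open whether any group on this triple-bonded carbon can move the number beyond the scatter, for example pyridin-4-yl, or a phenyl ring carrying an amine or a carboxylic acid. They also leave open whether pyridin-2-yl in place of phenyl would give a similar step on the core of compound 1, with its different chain, or alongside the methoxy group of compound 3.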